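The source may report more compounds than this note shows. Statements on the series, on what has been measured and on what is new or still open speak of the compounds shown alone.

Compound 1 `COc1ccc2c(C3CC(c4ccncc4)=NO3)c[nH]c2c1`: 4160 nM
Compound 2 `c1ccc2c(C3CC(c4ccncc4)=NO3)c[nH]c2c1`: > 100000 nM

Both compounds were tested in a functional assay on HEK293 cells (Homo sapiens) for inhibition, read by MTT assay, with a stated time of 48 h; on this read-out lower numbers stand for stronger inhibition and higher numbers for weaker inhibition. Compound 2 gives > 100000 nM, which is a limit of the assay and not a number. It therefore marks only (the limit of > 100000 nM in this assay, at which 1 of the 2 values shown sits), and any comparison with it has an open end.

Compound 3 `Fc1ccc2c(C3CC(c4ccncc4)=NO3)c[nH]c2c1` differs from compound 2 by fluoro in place of hydrogen on an aromatic carbon, (fluoro in place of hydrogen on an aromatic carbon). Among the measured compounds shown here, one measured step bears on this change: an at least 24-fold higher number from compound 1 to compound 2 (1.38 log units; beyond the scatter). That step is large and lies beyond the scatter, and it concerns the same aromatic carbon, where hydrogen replaces methoxy. Read in reverse, it suggests that a group other than hydrogen on that carbon may give a lower number. However, fluoro is not methoxy, and this single pair cannot show how much of the step carries over. Only part of it is expected, and compound 3 may still reach the limit of the assay.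

The expected step is an at least 3.3-fold lower number from compound 2 to compound 3 (0.52 log units; beyond the scatter). For compound 3 the estimated value is 30000 nM, with an expected range from 6000 nM to 100000 nM.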

Compound 3, half-maximal inhibitory concentration: 9500 nM
Estimate against measurement, compound 3: 3.2-fold (0.50 log units) above, and the stated range covers the measured number.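

In this assay, methoxy was so far the only group shown to lift this aromatic carbon clear of the limit, and fluoro now does the same, with an at least 10-fold lower number from compound 2 to compound 3 (1.02 log units; beyond the scatter). Going by these compounds, the true size of that step stays open, as the value of compound 2 is a limit of the assay and not a number: the limit of > 100000 nM in this assay, at which 1 of the 3 values shown sits. The two substituents can now also be set against each other directly, and with a 2.3-fold higher number from compound 1 to compound 3 (0.36 log units; beyond the scatter) the gap between them is modest yet beyond the scatter, so replacing hydrogen on this carbon with either group gives a far lower number, and methoxy keeps a small edge over fluoro.

Two groups on one carbon do not show how a chloro group, a hydroxyl group, an amine or a nitrile would compare with fluoro and methoxy at this place, so no trend across substituents can be drawn yet. Nor do these compounds tell whether fluoro or methoxy on another carbon of the same six-membered aromatic ring would give a similar drop from the limit seen for compound 2.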